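Shortening the difluoroalkyl chain: from compound 2 to compound 3

This account rests on a few compounds, and the source may have more. Where it says the series, first, only, none or still open, it means among the compounds named here.

Measured so far:
- compound 1, `COCc1nc2nc(C)cc(Nc3ccc(S(F)(F)(F)(F)F)cc3)n2n1`: 2.8
- compound 2, `CCC(F)(F)c1nc2nc(C)cc(Nc3ccc(S(F)(F)(F)(F)F)cc3)n2n1`: 3.9

Of the compounds shown here, two sharing one core have been measured in a physicochemical assay for lipophilicity, at pH 7.4; a lower number here means a more polar compound, a higher number a more lipophilic compound. Compound 1 `COCc1nc2nc(C)cc(Nc3ccc(S(F)(F)(F)(F)F)cc3)n2n1` gives 2.8 in this assay. Compound 2 `CCC(F)(F)c1nc2nc(C)cc(Nc3ccc(S(F)(F)(F)(F)F)cc3)n2n1` gives 3.9 in this assay, the higher of the two numbers, and the single step shown, a number 1.10 log units higher from compound 1 to compound 2 (beyond the scatter), came with 1,1-difluoropropyl in place of methoxymethyl on an aromatic carbon.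

The next compound, compound 3 `Cc1cc(Nc2ccc(S(F)(F)(F)(F)F)cc2)n2nc(C(C)(F)F)nc2n1`, keeps everything of compound 2 except one point: hydrogen in place of methyl on a saturated chain carbon, two bonds along the chain from an aromatic carbon and two fluorine atoms. Read one bond further out, this is ethyl to methyl, or 1,1-difluoropropyl to 1,1-difluoroethyl.

Among the measured compounds shown here, no measured step mirrors this change; the step from compound 1 to compound 2 swapped one whole group for another and so bears on it only loosely. Trimming a carbon from a saturated chain usually shifts a distribution coefficient by a small to moderate amount downward, so a modest drop is expected, a number 0.50 log units lower from compound 2 to compound 3 (beyond the scatter). Compound 3 is therefore estimated at 3.4 in this assay, within 3 to 3.8.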

Compound 3, distribution coefficient: 3.6
Compound 3: the middle estimate sits 0.20 log units below what was measured; low and high end bracket the measured number.
By their numbers in this assay, from the lowest: compound 1; then compounds 3 and 2 (each within the scatter of the next).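

In this assay, hydrogen in place of methyl on this saturated chain carbon gives a number 0.30 log units lower from compound 2 to compound 3 (within the scatter) and so 1,1-difluoropropyl and 1,1-difluoroethyl cannot be told apart here, even though the chain has lost a carbon. The earlier jump is also not confined to the longer group: replacing methoxymethyl with 1,1-difluoroethyl gives a number 0.80 log units higher from compound 1 to compound 3 (beyond the scatter) and this step, like a number 1.10 log units higher from compound 1 to compound 2 (beyond the scatter) before it, lies beyond the scatter, so both difluoroalkyl groups stand clear of methoxymethyl on the shared core. Nothing available here gives a measured reason for either step.

These compounds leave open how far the chain can change before the number moves beyond the scatter, which a longer chain such as 1,1-difluorobutyl or a shorter group such as difluoromethyl would test at the same position. They also leave open what the two fluorine atoms contribute, since every difluoroalkyl group here is compared only with methoxymethyl or with another difluoroalkyl group, and a plain ethyl or propyl chain would separate the fluorine atoms from the carbon chain.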